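Chloro to fluoro on the aromatic ring of compound 2

This account rests on a few compounds, and the source may have more. Where it says the series, first, only, none or still open, it means among the compounds named here.

Two compounds have numbers in a functional assay on L1210 cells (Mus musculus) for cytotoxicity; a higher number here means a weaker inhibitor, a lower number a stronger inhibitor. Compound 1 `Oc1ccccc1/C=N/c1ccc(F)c(Cl)c1` gives 68000 nM in this assay. Compound 2 `NC(=S)N/N=C/c1ccccc1Cl` gives 84000 nM, the higher of the two numbers, though its gap to compound 1 lies within the scatter, so no order between them can be read. Compound 3 `NC(=S)N/N=C/c1ccccc1F` differs from compound 2 by fluoro in place of chloro on an aromatic carbon. Within the data shown here, no measured pair shows this exchange, so nothing measured fixes its direction. The expected step from compound 2 to compound 3 is a 1.2-fold higher number from compound 2 to compound 3 (0.08 log units; within the scatter), no larger than the scatter. Compound 3 is estimated at 100000 nM, with a range from 40000 nM to 250000 nM.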

Compound 3, half-maximal inhibitory concentration: 242000 nM
Compound 3: middle estimate off by 2.4-fold (0.38 log units), on the low side, within the range that was stated.
By their numbers in this assay, from the lowest: compounds 1 and 2 (each within the scatter of the next); then compound 3.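

In this assay, fluoro in place of chloro on this aromatic carbon, ortho to a group of 6 heavy atoms, gives a 2.9-fold higher number from compound 2 to compound 3 (0.46 log units; beyond the scatter), so the read-out at this position responds to the choice of halogen, with fluoro the weaker of the two. The earlier compounds shown here offered no such pair, and this single modest step is all that supports the trend. No evidence at hand bears on what lies behind the step.

On these data alone, whether a bromo, a methyl or a methoxy group at this position would track with chloro or with fluoro remains open. Also open, as far as these compounds go, is whether the same exchange gives a step of similar size at other carbons of the ring.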